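A few compounds are considered here, and "the series" means these few. Any claim that something is new, unique, unknown or untested is made for them only; others in the source may bear on it.

Measured in a physicochemical assay for solubility, read by HPLC, in phosphate buffer, measured as kinetic solubility, at pH 7.4; on this read-out lower numbers stand for lower solubility and higher numbers for higher solubility:
- compound 1 `CCOC(=O)c1cc(-c2ccc(Cl)cc2)n(-c2ccc3cc[nH]c3c2)c1C`: 5100 nM
- compound 2 `CCOC(=O)c1cc(-c2ccc(F)cc2)n(-c2ccc(S(N)(=O)=O)cc2)c1`: 36400 nM
- compound 3 `CCC(=O)c1cc(-c2ccc(S(N)(=O)=O)cc2)n(-c2ccc(Cl)cc2)n1`: 41900 nM

Compound 3 gives 41900 nM. Compound 2 gives 36400 nM. Compound 1 gives 5100 nM. The values of compound 2 and compound 3 lie within the scatter of each other. The value of compound 1 is lower than that of compound 3, and that gap lies beyond the scatter. Compound 4 `CC(=O)c1cc(-c2ccc(S(N)(=O)=O)cc2)n(-c2ccc(Cl)cc2)n1` is not yet measured. It departs from compound 3 by one change: hydrogen in place of methyl on a saturated chain carbon bound to a carbonyl carbon, so propanoyl becomes acetyl. For the measured compounds named here, no measured pair here isolates this change, so the expectation stays anchored on compound 3 at 41900 nM, with no step beyond the scatter in this assay. The expected step is a 1.1-fold higher number from compound 3 to compound 4 (0.06 log units; within the scatter), a small upward one at most. For compound 4 the estimated value is 48000 nM, with an expected range of 25000 nM to 90000 nM.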

Compound 4, solubility: 86800 nM
Beside the measured number, compound 4's estimate is 1.8-fold (0.26 log units) below it; the measured number falls inside the stated range.
By their numbers in this assay, from the lowest: compound 1; then compounds 2 and 3 (each within the scatter of the next); then compound 4.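

In this assay, for the compounds shown here, the change from propanoyl to acetyl gives a 2.1-fold higher number from compound 3 to compound 4 (0.32 log units; beyond the scatter) and is the first single change that can be read. Going by these compounds alone, the saturated chain carbon bound to a carbonyl carbon is therefore not a silent place on this read-out, though only this one pair shows it. Nothing on hand gives a reason for the step.

As far as these compounds go, a longer chain such as butanoyl, or an amine at this place, remains open. So does whether the step carries over to the core of compound 1 or compound 2.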